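A Second Chloro on the Core, Seen Twice

The source may hold more compounds than are shown below. What is called first, only, known or untested is meant among the compounds shown, and "the series" means these compounds.

Compound 1 `ClCc1ccccc1Cn1cnc2c(Cl)nc(Cl)nc21` and compound 2 `ClCc1ccccc1Cn1cnc2c(Cl)ncnc21` share a core and differ only by chloro in place of hydrogen on an aromatic carbon. In a functional assay on SW-620 cells (Homo sapiens) for cytotoxicity, read by sulforhodamine B assay, with a stated time of 48 h (on this read-out lower numbers stand for stronger inhibition of growth and higher numbers for weaker inhibition of growth), compound 1 gives 150 nM, while compound 2 gives 1770 nM, so the step of a 12-fold lower number from compound 2 to compound 1 (1.07 log units; beyond the scatter) is large. Compound 3 `ClCc1cccc(Cn2cnc3c(Cl)ncnc32)c1` has the same atoms as compound 2 joined differently; the difference between the two cores is not broken down here. In this assay compound 3 gives 2130 nM, a value within the scatter of compound 2. For the measured compounds named here, compound 4 `ClCc1cccc(Cn2cnc3c(Cl)nc(Cl)nc32)c1` is not yet measured and differs from compound 3 by chloro in place of hydrogen on an aromatic carbon, the same change, at a place described in the same words, as the one separating compound 2 and compound 1. Resting on the measured step of a 12-fold lower number from compound 2 to compound 1 (1.07 log units; beyond the scatter), a step of about an 11-fold lower number from compound 3 to compound 4 (1.03 log units; beyond the scatter) is expected. Compound 4 is therefore estimated at 200 nM, likely between 80 nM and 600 nM.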

Compound 4, concentration for 50% growth inhibition: 1580 nM
For compound 4 the middle estimate is 7.9-fold (0.90 log units) below the measured one, outside the stated range (above it).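

The same chloro group, placed on the aromatic carbon between two ring nitrogen atoms, gives a much smaller change on the second core: in this assay the new step is a 1.3-fold lower number from compound 3 to compound 4 (0.13 log units; within the scatter) and so stays within the usual scatter. Set beside the earlier step, the two results clearly disagree: the same change on two cores in this assay, a 12-fold lower number (1.07 log units; beyond the scatter) from compound 2 to compound 1 and a 1.3-fold lower number (0.13 log units; within the scatter) from compound 3 to compound 4, 8.8-fold (0.94 log units) apart, beyond the scatter of two such steps. This shows that the size of this change on one core cannot simply be carried over to the other in this series, but it does not show why the two cores differ.

Going by these compounds, what an amine or a methoxy group would do at that same carbon remains open. With only two cores shown, it is also open which step a further core would resemble.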